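The source may hold more compounds than are shown below. What is called first, only, known or untested is meant among the compounds shown, and "the series" means these compounds.

Measured compounds, with their numbers in an assay on microsomes from brain for inhibition of Fatty-acid amide hydrolase 1 (Rattus norvegicus), read by fluorescence and HPLC, with a stated time of 45 min; on this read-out lower numbers stand for stronger inhibition and higher numbers for weaker inhibition:
- compound 1 `O=C(COc1ccc(Oc2ccccc2)cc1)Cn1ncnn1` gives 8 nM
- compound 2 `O=C(COc1ccc(Oc2ccccc2)cc1)Cn1ncc2cc(NC(=O)Oc3ccccc3)ccc21` gives 2100 nM
- compound 3 `O=C(COc1ccc(Oc2ccccc2)cc1)Cn1ncc2cc(C(=O)NS(=O)(=O)c3ccccc3)ccc21` gives 4700 nM

Among these three numbers compound 2 stands second highest. Its nearest neighbour is compound 3, reached by a 2.2-fold higher number from compound 2 to compound 3 (0.35 log units; beyond the scatter), a modest step that exchanges one group on an aromatic carbon of the shared core. Compound 1, built on a far smaller core, gives a number far below that of compound 2.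

The unmeasured compound 4 `O=C(COc1ccc(Oc2ccccc2)cc1)Cn1ncc2cc(C(=O)NS(=O)(=O)C(F)(F)F)ccc21` differs from compound 2 in one place: ((trifluoromethyl)sulfonyl)carbamoyl in place of (phenoxycarbonyl)amino on an aromatic carbon. Among the measured compounds shown here, only one measured step bears on this change, the step from compound 2 to compound 3, because a 2.2-fold higher number from compound 2 to compound 3 (0.35 log units; beyond the scatter) also replaces the (phenoxycarbonyl)amino group with a sulfonylcarbamoyl group on the same aromatic carbon. For the measured compounds named here, compound 4 carries a trifluoromethyl group on the sulfonyl where compound 3 carries a phenyl ring, and no measured pair shows what that exchange does. The expectation for compound 4 therefore rests on the measured step from compound 2 to compound 3. The expected change is a modest rise in the number, a 1.9-fold higher number from compound 2 to compound 4 (0.28 log units; within the scatter). Compound 4 is estimated at 4000 nM, within a range from 1500 nM to 12000 nM.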

Compound 4, half-maximal inhibitory concentration: 510 nM
The estimate for compound 4 lay 7.8-fold (0.89 log units) above the measured number; the whole stated range lies above it.
By their numbers in this assay, from the lowest: compound 1; then compound 4; then compound 2; then compound 3.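

In this assay the step of a 4.1-fold lower number from compound 2 to compound 4 (0.61 log units; beyond the scatter) runs opposite to the step of a 2.2-fold higher number from compound 2 to compound 3 (0.35 log units; beyond the scatter), so replacing the (phenoxycarbonyl)amino group on this aromatic carbon with a sulfonylcarbamoyl group does not by itself set the direction of the change. Among the compounds shown here, the outcome at this position depends on what the sulfonyl sulfur carries: the step of a 9.2-fold lower number from compound 3 to compound 4 (0.96 log units; beyond the scatter), with trifluoromethyl in place of phenyl, is the first measured exchange at that sulfur, and it lowers the number beyond the scatter. Nothing available explains why trifluoromethyl and phenyl on the sulfur part compound 4 and compound 3 in this way.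

With only phenyl and trifluoromethyl shown on the sulfur, it remains open whether a methyl group or a cyclopropyl ring there would give a number closer to that of compound 4 or to that of compound 3. Also open, going by these compounds, is how a carboxylic acid or a simple primary amide on the same aromatic carbon of the shared core, with no sulfonyl group at all, would compare with compound 4.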